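The source may report more compounds than this note shows. Statements on the series, on what has been measured and on what is new or still open speak of the compounds shown alone.

Compound 3 `Cc1cc(C)c(S(=O)(=O)N[C@@H](CNC(=O)C2=NO[C@]3(C2)C[C@@H](CNc2ncc[nH]2)N(C(=O)OCc2ccccc2)C3)C(=O)O)c(C)c1` gives the lowest number of the three compounds tested in a functional assay for antagonist activity at integrin alpha-5/beta-1 (Homo sapiens), read by ELISA (on this read-out higher numbers stand for weaker inhibition and lower numbers for stronger inhibition), at 18 nM. Compound 1 `Cc1cc(C)c(S(=O)(=O)N[C@@H](CNC(=O)C2=NO[C@]3(CN[C@H](CNc4ncc[nH]4)C3)C2)C(=O)O)c(C)c1` gives 230 nM in this assay, and the step of a 13-fold lower number from compound 1 to compound 3 (1.11 log units; beyond the scatter) is large. Compound 2 `Cc1cc(C)c(S(=O)(=O)N[C@@H](CNC(=O)C2=NO[C@@]3(C2)C[C@@H](CNC2N=CC=N2)N(C(=O)OCc2ccccc2)C3)C(=O)O)c(C)c1` gives 1200 nM in this assay; it carries the non-aromatic ring that enters in compound 4, but it is drawn with the opposite arrangement at the spiro carbon, so it offers only an indirect hint. Compound 4 `Cc1cc(C)c(S(=O)(=O)N[C@@H](CNC(=O)C2=NO[C@]3(C2)C[C@@H](CNC2N=CC=N2)N(C(=O)OCc2ccccc2)C3)C(=O)O)c(C)c1` differs from compound 3 by a group of 5 heavy atoms (3 carbon, 2 nitrogen; one five-membered non-aromatic ring with 2 hetero atoms) in place of a group of 5 heavy atoms (3 carbon, 2 nitrogen; one five-membered aromatic ring with 2 hetero atoms), on an amine nitrogen. Within the data shown here, no measured step isolates this change. Since compound 2 gives 1200 nM, a clearly higher number than compound 3 is expected for compound 4 in this assay, roughly a 17-fold higher number from compound 3 to compound 4 (1.22 log units; beyond the scatter), so compound 4 is estimated at 300 nM, within 30 nM to 3000 nM.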

Compound 4, half-maximal inhibitory concentration: 13 nM
Estimate against measurement, compound 4: 23-fold (1.36 log units) above; measured number below the stated range.
By their numbers in this assay, from the lowest: compounds 4 and 3 (each within the scatter of the next); then compound 1; then compound 2.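

With the aromatic 1H-imidazol-2-yl and the non-aromatic five-membered ring on this amine nitrogen, the two compounds cannot be told apart in this assay (a 1.4-fold lower number from compound 3 to compound 4 (0.14 log units; within the scatter)). In this pair, then, an aromatic ring at this position is not needed to keep the low number. The step of a 92-fold lower number from compound 2 to compound 4 (1.97 log units; beyond the scatter) is large, and it can be traced to a single difference: the fact that compounds 2 and 4 differ only in the configuration as drawn.

On these data alone, it remains open whether a pyrimidin-2-yl group on the same nitrogen would hold this number, and whether the non-aromatic ring would do so with hydrogen in place of benzyloxycarbonyl.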